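This account rests on a few compounds, and the source may have more. Where it says the series, first, only, none or still open, it means among the compounds named here.

In a functional assay on MDA-MB-231 cells (Homo sapiens) for antiproliferative activity, read by MTT assay, with a stated time of 72 h (a higher number here means a weaker inhibitor, a lower number a stronger inhibitor), compound 1 `S=C(SSC1CCCCC1)N1CCCC1` gives 4700 nM as its half-maximal concentration. Compound 2 `CCCCSSC(=S)N(CC)CC` stands at 7400 nM and compound 3 `CCCCSSC(=S)N1CCCCC1` at 8000 nM on the same scale, so all three lie within the usual scatter of one another and cannot be told apart.

Compound 4 `CCN(CC)C(=S)SSC1CCCCC1` has not been measured yet. It keeps the core of compound 1 and carries diethylamino in place of pyrrolidin-1-yl on a thiocarbonyl carbon. The count diethylamino in place of pyrrolidin-1-yl on a thiocarbonyl carbon sums up this swap, in which the entering group has no ring.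

Among the measured compounds shown here, no pair of measured compounds isolates this change, so the evidence is indirect. Compound 2 also carries diethylamino, and its 7400 nM does not stand apart from the other two values. Only a small change is therefore expected, with the step of a 1.2-fold higher number from compound 1 to compound 4 (0.07 log units; within the scatter) estimated to stay within the scatter. For compound 4 the expected value is 5500 nM with an estimated range of 2500 nM to 12000 nM in all likelihood.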

Compound 4, half-maximal inhibitory concentration: 960 nM
Compound 4: the middle estimate sits 5.7-fold (0.76 log units) above what was measured; the whole stated range lies above it.
By their numbers in this assay, from the lowest: compound 4; then compounds 1, 2 and 3 (each within the scatter of the next).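

In this assay, the step of a 4.9-fold lower number from compound 1 to compound 4 (0.69 log units; beyond the scatter) is the first difference among these compounds that lies beyond the scatter, so the group on a thiocarbonyl carbon can change the result even when the ring of pyrrolidin-1-yl gives way to diethylamino with the same count of heavy atoms. Diethylamino does not guarantee a low number, however: compound 2 also carries it and gives 7400 nM, with butyl where compound 4 has cyclohexyl. No measurement shown here accounts for the gain with diethylamino.

It remains open whether the gain holds only alongside cyclohexyl, as no compound shown pairs pyrrolidin-1-yl with butyl. Also unsettled is how a longer chain such as dipropylamino, or a morpholin-4-yl ring, would fare in this same place.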